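This account rests on a few compounds, and the source may have more. Where it says the series, first, only, none or still open, it means among the compounds named here.

For the measured compounds named here, compound 2, with the structure `OC[C@@H]1C[C@H](CO)[C@@H]2C(c3ccc(Cl)cc3)=NO[C@H]12`, is the one compound of the three with a number rather than a limit: in a functional assay on MCF7 cells (Homo sapiens) for cytotoxicity, read by MTT assay, with a stated time of 48 h (on this read-out higher numbers stand for weaker inhibition and lower numbers for stronger inhibition), compound 2 gives 14.7 ug/mL. Compound 1, `OC[C@@H]1C[C@H](CO)[C@@H]2C(c3ccccc3Cl)=NO[C@H]12`, reaches only the limit of this assay, > 50 ug/mL. Compound 3, `OC[C@@H]1C[C@H](CO)[C@@H]2C(c3ccc(F)cc3)=NO[C@H]12`, likewise gives a limit in this assay, > 50 ug/mL. Going by the values given here, the single step with two measured ends, an at least 3.4-fold higher number from compound 2 to compound 3 (0.53 log units; beyond the scatter), shows weaker inhibition once fluoro stands in place of chloro, and the limit of > 50 ug/mL in this assay, at which 2 of the 3 values shown sit, caps how much of that weakening can be seen. Compound 4, `COc1ccc(C2=NO[C@@H]3[C@H](CO)C[C@H](CO)[C@H]23)cc1`, differs from compound 2 by methoxy in place of chloro on an aromatic carbon. Among the compounds with values here, no measured step carries a methoxy, so the expectation rests on the loss seen with fluoro in place of chloro; a weakening of about a 2.0-fold higher number from compound 2 to compound 4 (0.31 log units; beyond the scatter) is expected. Compound 4 is therefore estimated at 30 ug/mL, between 10 ug/mL and 60 ug/mL.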

Compound 4, half-maximal inhibitory concentration: 23.7 ug/mL
Beside the measured number, compound 4's estimate is 1.3-fold (0.10 log units) above it, and the stated range covers the measured number.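

In this assay, methoxy in place of chloro on this aromatic carbon gives a 1.6-fold higher number from compound 2 to compound 4 (0.21 log units; within the scatter), so unlike fluoro, this change shows no loss beyond the scatter. Chloro is therefore not the only group here that gives a measured number, and methoxy in place of fluoro gives an at least 2.1-fold lower number from compound 3 to compound 4 (0.32 log units; beyond the scatter). The true size of that step stays unknown because compound 3 sits at a limit: the limit of > 50 ug/mL in this assay, at which 2 of the 4 values shown sit.

The compounds shown leave open how an amine, a hydroxyl or a longer chain such as ethoxy would fare at this position.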